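This account rests on a few compounds, and the source may have more. Where it says the series, first, only, none or still open, it means among the compounds named here.

Measured in a functional assay on RAW264.7 cells (Rattus norvegicus) for inhibition, with RAW264.7 (Mus musculus) as the target, read by Griess assay, with a stated time of 24 h; on this read-out lower numbers stand for stronger inhibition and higher numbers for weaker inhibition:
- Compound 1 `CC(C)CC(=O)OCC1=CO[C@@H](OC(=O)CC(C)C)[C@H]2C1=C[C@H](O)[C@]2(O)CO`: > 50000 nM, a limit of the assay and not a number.
- Compound 2 `CC(C)CC(=O)OCC1=CO[C@H](OC(=O)CC(C)C)[C@@H]2[C@@](O)(COC(=O)CC(C)C)[C@H](O)C[C@]12O`: 26000 nM.

Among the compounds with values here, compound 2 gives 26000 nM, the only true number so far, so it is the single reference point. Compound 3 `CC(C)CC(=O)OCC1=CO[C@H](OC(=O)CC(C)C)[C@H]2C1(O)C[C@@H](O)[C@]2(O)COC(=O)CC(C)C` is compared with it: the two compounds have the same atoms and bonds; at least one stereo element is drawn with a configuration in one of them and without one in the other: 1 of 5 stereo elements differ; a stereocentre at a saturated ring carbon is drawn R in compound 2 and without a configuration in compound 3. In other words, a stereocentre at a saturated ring carbon is drawn R in compound 2 and without a configuration in compound 3. Within the data shown here, no measured pair shows what such a change does, so no shift beyond the usual scatter is expected in this assay, in either direction. The expected change is a 1.1-fold higher number from compound 2 to compound 3 (0.03 log units; within the scatter). Compound 3 is estimated at 28000 nM, with an expected range from 13000 nM to 50000 nM.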

Compound 3, half-maximal inhibitory concentration: 14700 nM
Compound 3: the middle estimate sits 1.9-fold (0.28 log units) above what was measured; low and high end bracket the measured number.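

In this assay, this pair gives a 1.8-fold lower number from compound 2 to compound 3 (0.25 log units; within the scatter) and is the only measured view of this saturated ring carbon, so drawing the stereocentre as R or leaving it undefined shows no shift beyond the usual scatter. That result cannot be read as a true comparison of two configurations, because of one fact: the fact that one of compounds 2 and 3 is drawn with a defined configuration and the other without, at the place where they differ.

From the compounds shown here alone, whether compound 3 is the R form, the opposite form or a mixture stays open. Also open, going by these compounds, is what a longer chain on the ester groups, or an amine in their place, would do.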